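A 4-ethylphenyl swap at the assay limit

The source may hold more compounds than are shown below. What is called first, only, known or untested is meant among the compounds shown, and "the series" means these compounds.

In a functional assay on A549 cells (Homo sapiens) for inhibition, read by sulforhodamine B assay, with a stated time of 48 h (a lower number here means that less compound is tolerated, a higher number that more compound is tolerated), compound 1 (`Cc1ccc(C2=NN(c3ccc(S(C)(=O)=O)cc3)C(=O)CC2)cc1`) gives > 100000 nM, which is a limit and not a number. Compound 2 (`Cc1cc(O)ccc1C1=NN(c2ccc(S(C)(=O)=O)cc2)C(=O)CC1`) gives > 100000 nM, also a limit and the same one: the limit of > 100000 nM in this assay, at which 2 of the 2 values shown sit. Compound 3 (`CCc1ccc(C2=NN(c3ccc(S(C)(=O)=O)cc3)C(=O)CC2)cc1`) carries 4-ethylphenyl in place of 4-hydroxy-2-methylphenyl on a carbon with a double bond to nitrogen. Because a step that the two limits leave unreadable from compound 1 to compound 2 offers no size to carry forward, no step beyond the scatter is expected in this assay. The expected change is a number no higher from compound 2 to compound 3 (the limit leaves the size open). Compound 3 is estimated at 100000 nM, with an expected range of 50000 nM to 200000 nM, and may well return only a limit.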

Compound 3, concentration lethal to 50% of the cells: > 100000 nM
Compound 3: only a limit was reported; the forecaster's own chance of this, stated with the estimate: 85%; the middle value sits exactly at the limit.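

Among these compounds, no step between compound 1, compound 2 and compound 3 can be read, since each returns only a limit and not a number: the limit of > 100000 nM in this assay, at which 3 of the 3 values shown sit. On these data alone, whether 4-methylphenyl, 4-hydroxy-2-methylphenyl or 4-ethylphenyl makes any difference to the lethal concentration stays open.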